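From methyl to trifluoromethyl: compound 3 to compound 4

The source may hold more compounds than are shown below. What is called first, only, known or untested is meant among the compounds shown, and "the series" means these compounds.

Measured in a functional assay on HEK293 cells (Homo sapiens) for cytotoxicity; a lower number here means that less compound is tolerated, a higher number that more compound is tolerated (each value a limit)
- compound 1 `COc1ccc([C@H]2CC(=O)N(c3ccc(C)c(N)c3)C2)cc1OC1CCCC1` gives > 10000 nM
- compound 2 `COc1ccc([C@H]2CC(=O)N(c3ccccc3N)C2)cc1OC1CCCC1` gives > 10000 nM
- compound 3 `COc1ccc([C@H]2CC(=O)N(c3ccc(C)cc3)C2)cc1OC1CCCC1` gives > 10000 nM

Compound 3 gives > 10000 nM in this assay and this is a limit, not a number. Compound 4 `COc1ccc([C@H]2CC(=O)N(c3ccc(C(F)(F)F)cc3)C2)cc1OC1CCCC1` carries trifluoromethyl in place of methyl on an aromatic carbon and is not yet measured. The steps bearing on it are a step that the two limits leave unreadable from compound 1 to compound 3 and a step that the two limits leave unreadable from compound 2 to compound 3 and also a step that the two limits leave unreadable from compound 1 to compound 2 and none has a size to carry over. The expectation rests on the limit of > 10000 nM in this assay, at which 3 of the 3 values shown sit, and no step beyond the scatter is expected in this assay in either direction. The estimated change is a step that the limit leaves unreadable from compound 3 to compound 4 and another limit is the likely report. Compound 4 is estimated at 20000 nM with an expected range from 8000 nM to 60000 nM for now.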

Compound 4, half-maximal cytotoxic concentration: > 10000 nM
Compound 4: only a limit was reported (the forecaster's own chance of this, stated with the estimate: 85%); the middle value lies beyond the limit too.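

In this assay compound 4 gives > 10000 nM, a limit and not a number. Its steps from compound 1, compound 2 and compound 3 therefore cannot be read. The compounds shown leave open at what concentration any of the four would reach half-maximal cytotoxicity.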